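The compounds below may be only part of what the source reports. "The series", "measured", "known", "first", "only" and "open" are said of these compounds alone.

Compound 1 `COC(=O)[C@@]1(C)CCC=C2[C@@H]1CC[C@@H](C)[C@]2(C)Cc1c[nH]c2ccc(Br)cc12` gives 20000 nM in a functional assay on WiDr cells (Homo sapiens) for inhibition, read by sulforhodamine B assay, with a stated time of 48 h; on this read-out lower numbers stand for stronger inhibition of growth and higher numbers for weaker inhibition of growth. Its partner compound 2 `COC(=O)[C@@]1(C)CCC=C2[C@@H]1CC[C@@H](C)[C@]2(C)Cc1c[nH]c2ccc(Cl)cc12` gives 20000 nM in this assay, so the change chloro in place of bromo on an aromatic carbon produced no change at the digits printed from compound 1 to compound 2 (within the scatter). Compound 3 `COC(=O)[C@@]1(C)CC[C@@H]2C3=C1CC[C@@H](C)[C@]3(C)C[C@@H]1c3cccc(Br)c3N[C@H]21` gives 54000 nM in this assay, the highest number of the three; how the core of compound 3 differs from the core of compound 1 is not broken down here. Compound 4 `COC(=O)[C@@]1(C)CC[C@@H]2C3=C1CC[C@@H](C)[C@]3(C)C[C@@H]1c3cccc(Cl)c3N[C@H]21` carries the change (chloro in place of bromo on an aromatic carbon). This is the same kind of change as the earlier one, though not the same: in compound 1 the ring is part of a fused or bridged system of two rings, meta and para to a fused ring, whereas in compound 3 it is part of a fused or bridged system of five rings, ortho and meta to a fused ring. Because no change at the digits printed from compound 1 to compound 2 (within the scatter) showed no change, compound 4 is expected to give a step of no change at the digits printed from compound 3 to compound 4 (within the scatter) in this assay. Compound 4 is therefore estimated at 54000 nM, with a likely range of 25000 nM to 110000 nM.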

Compound 4, concentration for 50% growth inhibition: 67000 nM
Compound 4: the middle estimate sits 1.2-fold (0.09 log units) below what was measured; the measured number falls inside the stated range.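

Chloro in place of bromo on an aromatic carbon gave, in this assay, a 1.2-fold higher number from compound 3 to compound 4 (0.09 log units; within the scatter), and set beside the earlier step, the change carried over between the two cores: the same change on two cores in this assay, no change at the digits printed (within the scatter) from compound 1 to compound 2 and a 1.2-fold higher number (0.09 log units; within the scatter) from compound 3 to compound 4, 1.2-fold (0.09 log units) apart, within the scatter of two such steps. On these two cores, then, exchanging one halogen for the other left the growth-inhibition number within the scatter, although the ring carrying it belongs to a fused system of a different size in each. This rests on two pairs only and does not show that the change would behave the same way on any further core.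

The compounds shown leave open whether fluoro, methoxy or an amine on that aromatic carbon would move the number. They also leave open what a carboxylic acid in place of the methyl ester would do.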